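The source may report more compounds than this note shows. Statements on the series, on what has been measured and on what is new or still open speak of the compounds shown alone.

Working notes on the series. Compound 1 `Cc1n[nH]cc1-c1cccc2c1CCC2c1ncc[nH]1` gives 91% in a functional assay on CHO cells for agonist activity at Alpha-1A adrenergic receptor (Homo sapiens), read by FLIPR and calcium flux; on this read-out lower numbers stand for smaller maximal responses and higher numbers for larger maximal responses. Compound 2 `Cn1ccc(-c2cccc3c2CCC3c2ncc[nH]2)n1` gives 19% in this assay. Compound 3 `c1ccc2c(c1)CCC2c1ncc[nH]1`, which carries only hydrogen at the position in question, gives 54% in this assay and stands second highest of the three numbers, with compound 2 nearest and compound 1 furthest. Compound 4 `c1cncc(-c2cccc3c2CCC3c2ncc[nH]2)c1` has not yet been measured in this assay; it differs from compound 3 by pyridin-3-yl in place of hydrogen on an aromatic carbon.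

Among the measured compounds shown here, two measured steps bear on this change, both replacing an aromatic group at the same carbon with hydrogen: a number 37 percentage points lower from compound 1 to compound 3 (beyond the scatter) and a number 35 percentage points higher from compound 2 to compound 3 (beyond the scatter). Together they show that an aromatic group on this carbon moves the maximal response by a large amount, but in opposite directions for the two pyrazoles. Pyridin-3-yl is a third, different group, so the direction of the step cannot be fixed from these data; a large step either way is possible. The step of a number 4 percentage points lower from compound 3 to compound 4 (within the scatter) is therefore estimated as small in the middle, with a wide range. For compound 4 a value of 50% is expected, between 18% and 85%.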

Compound 4, largest response reached (Emax), in percent of the reference or control that the assay uses: 36%
Compound 4: the middle estimate sits 14 percentage points above what was measured, within the range that was stated.
By their numbers in this assay, from the lowest: compound 2; then compound 4; then compound 3; then compound 1.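

In this assay the pyridin-3-yl change gives a number 18 percentage points lower from compound 3 to compound 4 (beyond the scatter) and so shows that a six-membered aromatic ring on this carbon lowers the maximal response relative to hydrogen, in the same direction as 1-methyl-1H-pyrazol-3-yl and against 3-methyl-1H-pyrazol-4-yl. Swapping between the aromatic groups gives a number 17 percentage points higher from compound 2 to compound 4 (beyond the scatter) and a number 55 percentage points lower from compound 1 to compound 4 (beyond the scatter) and places the three at separate levels, so an aromatic group here does not by itself raise the response, and only 3-methyl-1H-pyrazol-4-yl in compound 1 exceeds hydrogen. No measurement at hand accounts for these differences.

Going by these compounds, the two pyrazoles differ in both methyl placement and attachment, so which of these features matters stays open. Also open, on these data alone, is how a non-aromatic group on this carbon, such as an amine, a carboxylic acid or a longer alkyl chain, compares with hydrogen.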